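Outer phenyl substituent: methyl to bromo

The source may report more compounds than this note shows. Statements on the series, on what has been measured and on what is new or still open speak of the compounds shown alone.

Compound 1 `N=C(N)c1ccc(-c2ccc(-c3ccc([N+](=O)[O-])cc3)o2)cc1` and compound 2 `Cc1ccc(-c2ccc(-c3ccc(C(=N)N)cc3)o2)cc1` share one core and differ only in the group carried on the outer phenyl ring. In an assay on isolated protein for inhibition of ribosyldihydronicotinamide dehydrogenase [quinone] (Homo sapiens), read by spectrophotometry, with a stated time of 1 min (on this read-out higher numbers stand for weaker inhibition and lower numbers for stronger inhibition), compound 1 gives 24 nM, and in this assay compound 2 gives 110 nM. Among the compounds with values here, compound 2 thus stands at the higher of the two numbers measured so far, separated from compound 1 by a 4.6-fold higher number from compound 1 to compound 2 (0.66 log units; beyond the scatter), so the group at this place does move the read-out, though modestly.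

Compound 3 `N=C(N)c1ccc(-c2ccc(-c3ccc(Br)cc3)o2)cc1` is the next member: bromo in place of methyl on an aromatic carbon. Within the data shown here, no measured step involves a bromo group, so the only bearing comes from the methyl-for-nitro step, which sets the scale of what a change at this place has done. Since nothing shows whether bromo falls nearer to methyl or to nitro, a small movement back toward the lower number is expected, with wide uncertainty. The expected step is a 1.8-fold lower number from compound 2 to compound 3 (0.26 log units; within the scatter). Compound 3 is estimated in this assay at 60 nM, with a range of 20 nM to 200 nM.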

Compound 3, half-maximal inhibitory concentration: 185 nM
Compound 3: the middle estimate sits 3.1-fold (0.49 log units) below what was measured; low and high end bracket the measured number.
By their numbers in this assay, from the lowest: compound 1; then compounds 2 and 3 (each within the scatter of the next).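

In this assay, the exchange of methyl for bromo gives a 1.7-fold higher number from compound 2 to compound 3 (0.23 log units; within the scatter) and so does not separate these two groups at this position on the outer phenyl ring. Bromo in place of nitro gives a 7.7-fold higher number from compound 1 to compound 3 (0.89 log units; beyond the scatter) and, like methyl in place of nitro, lies beyond the scatter, so among the three groups shown, nitro alone stands apart, with compound 1 holding the lowest number and therefore the strongest inhibition of the series so far. No accompanying data bear on why the nitro compound separates from the other two, or on why bromo and methyl cannot be told apart here.

From the compounds shown here alone, whether the separation of compound 1 belongs to nitro alone or would be shared by other groups at this place, such as a nitrile, a carboxylic acid or an amine, stays open, as does the level of the unsubstituted phenyl ring. Also open, going by these compounds, is whether the match between bromo and methyl extends to fluoro, chloro or a larger alkyl group such as tert-butyl, and whether these step sizes hold after a change elsewhere on the shared core.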